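The source may report more compounds than this note shows. Statements on the series, on what has been measured and on what is new or still open speak of the compounds shown alone.

Working notes on the series. Going by the values given here, compound 1 `CN1CCN(c2ccn3c(-c4ccc(NC(=O)c5ccc([N+](=O)[O-])o5)cc4)cnc3c2)CC1` in a functional assay on AGS cells (Homo sapiens) for antiproliferative activity, read by CCK-8 assay, with a stated time of 72 h (on this read-out lower numbers stand for stronger inhibition and higher numbers for weaker inhibition), gives 2340 nM; compound 2 `O=C(Nc1ccc(-c2cnc3cc(C4=CCN(C5COC5)CC4)ccn23)cc1)c1ccc([N+](=O)[O-])o1` in this assay gives 790 nM, the lowest of the two numbers so far. Compound 3 `CC1(O)CCN(c2ccn3c(-c4ccc(NC(=O)c5ccc([N+](=O)[O-])o5)cc4)cnc3c2)CC1` differs from compound 2 by a group of 8 heavy atoms (6 carbon, 1 nitrogen, 1 oxygen; one six-membered non-aromatic ring with 1 hetero atom) in place of a group of 10 heavy atoms (8 carbon, 1 nitrogen, 1 oxygen; one four-membered non-aromatic ring with 1 hetero atom, one six-membered non-aromatic ring with 1 hetero atom), on an aromatic carbon. Among the compounds with values here, the only measured step bearing on this carbon is a 3.0-fold lower number from compound 1 to compound 2 (0.47 log units; beyond the scatter), where the group with one six-membered non-aromatic ring with 2 hetero atoms gave the higher number. Compound 3 again carries a single six-membered non-aromatic ring there, so a move partway back is expected, estimated as a 1.9-fold higher number from compound 2 to compound 3 (0.28 log units; within the scatter). Compound 3 is expected to give about 1500 nM, within 600 nM to 4000 nM.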

Compound 3, half-maximal inhibitory concentration: 1530 nM
Compound 3: middle estimate off by 1.0-fold (0.01 log units), on the low side; measured number inside the range.
By their numbers in this assay, from the lowest: compounds 2, 3 and 1 (each within the scatter of the next, the first and the last beyond it).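

In this assay, 4-hydroxy-4-methylpiperidin-1-yl on this aromatic carbon cannot be separated from either earlier group: the steps are a 1.9-fold higher number from compound 2 to compound 3 (0.29 log units; within the scatter) and a 1.5-fold lower number from compound 1 to compound 3 (0.18 log units; within the scatter). Only compound 1 and compound 2 stand apart, so adding a hydrogen-bond donor to the group here produces no step beyond the scatter. No available measurement explains this result.

Going by these compounds, it remains open whether the hydroxyl or the methyl of this group matters on its own. A primary amine or a carboxylic acid on this carbon also remains untested in the compounds shown.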